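Replacing the amide substituent: from compound 1 to compound 4

The compounds below may be only part of what the source reports. "The series", "measured", "known", "first", "only" and "open" are said of these compounds alone.

Compound 1: `CCOC(=O)c1sc(-c2cccc(NC(=O)c3ccc(C(C)(C)C)cc3)c2)nc1Nc1ccc(N2CCN(C)CC2)cc1` — 4.22%
Compound 2: `CCOC(=O)c1sc(-c2cccc(NC(=O)c3ccccc3)c2)nc1Nc1ccc(N2CCN(C)CC2)cc1` — 42%
Compound 3: `CCOC(=O)c1sc(-c2cccc(NC(=O)c3ccccc3F)c2)nc1Nc1ccc(N2CCN(C)CC2)cc1` — 89.8%

In a functional assay on Raji cells (Homo sapiens) for antiproliferative activity, read by CCK-8 assay, with a stated time of 72 h, tested at 40 uM (a higher number here means more inhibition at the concentration tested (going by the name of the read-out), a lower number less inhibition), compound 1 gives 4.22%, the lowest of the three measured numbers; compound 2 sits next to it and compound 3 furthest away. The step from compound 1 to compound 4 `CCOC(=O)c1sc(-c2cccc(NC(=O)c3ccc(C(F)(F)F)cn3)c2)nc1Nc1ccc(N2CCN(C)CC2)cc1` is 5-(trifluoromethyl)pyridin-2-yl in place of 4-(tert-butyl)phenyl on a carbonyl carbon. For the measured compounds named here, two measured steps bear on this change, both departing from the same 4-(tert-butyl)phenyl group of compound 1: a number 37.8 percentage points higher from compound 1 to compound 2 (beyond the scatter) and a number 85.6 percentage points higher from compound 1 to compound 3 (beyond the scatter). Each time the 4-(tert-butyl)phenyl group was exchanged, the number in this assay rose by a large amount, beyond the scatter. A third step, a number 47.8 percentage points higher from compound 2 to compound 3 (beyond the scatter), shows that what enters in place of it also matters strongly, so the size of the rise for compound 4 is uncertain. Compound 4 is therefore expected to lie higher than compound 1, and the estimated step is a number 35.8 percentage points higher from compound 1 to compound 4 (beyond the scatter). For compound 4 the expected value in this assay is 40%, with a range from 10% to 80%.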

Compound 4, a percentage reported as inhibition, at one concentration (the size of the read-out at that concentration, not a potency): 20.8%
For compound 4 the middle estimate is 19.2 percentage points above the measured one; the measured number falls inside the stated range.
By their numbers in this assay, from the lowest: compound 1; then compound 4; then compound 2; then compound 3.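

In this assay leaving the 4-(tert-butyl)phenyl group again gives a rise, this time only a number 16.6 percentage points higher from compound 1 to compound 4 (beyond the scatter) and thus the smallest of the rises seen on leaving that group. The 5-(trifluoromethyl)pyridin-2-yl group also falls short of the simpler rings on the same carbonyl carbon, with a number 21.2 percentage points lower from compound 2 to compound 4 (beyond the scatter) and a number 69 percentage points lower from compound 3 to compound 4 (beyond the scatter) as its steps from phenyl and 2-fluorophenyl. Removing the 4-(tert-butyl)phenyl group is therefore not enough to reach the level of compound 2 or compound 3, and the group that enters largely sets the outcome.

The compounds shown do not separate the ring nitrogen from the trifluoromethyl group, so a plain pyridin-2-yl group or a trifluoromethylphenyl group remains an open case. Nothing given here explains these differences.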